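Swapping an Isobutyl for a Propanoyl on a Chromone

This account rests on a few compounds, and the source may have more. Where it says the series, first, only, none or still open, it means among the compounds named here.

The three measured compounds share a core and differ in the groups hung around it. Compound 1, `Cc1ccc2c(=O)cc(/C=C/[S+](C)[O-])oc2c1`, gives 7000 nM in a functional assay on DLD-1 cells (Homo sapiens) for cytotoxicity, with a stated time of 48 h; a lower number here means a stronger inhibitor, a higher number a weaker inhibitor. Compound 2, `CC(C)COc1ccc2oc(/C=C/[S+](C)[O-])cc(=O)c2c1`, gives 5000 nM in this assay. Compound 3, `C[S+]([O-])/C=C/c1oc2ccccc2c(=O)c1Cc1ccccc1`, gives 5100 nM in this assay. Compound 2 holds the lowest of the three numbers, but its gap to compound 3 and its gap to compound 1 both lie within the scatter of repeated measurements, so the three read as much the same.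

Compound 4, `CCC(=O)Oc1ccc2oc(/C=C/[S+](C)[O-])cc(=O)c2c1`, has not yet been measured. It differs from compound 2 in one place: propanoyl in place of isobutyl on an oxygen on an aromatic ring. Within the data shown here, no step of this kind between measured compounds is available, so nothing directly shows how this change plays out. Because compound 1 gives 7000 nM and compound 3 gives 5100 nM while compound 2 gives 5000 nM in this assay, all clustering together, the most reasonable expectation is a step from compound 2 to compound 4 of about a 1.2-fold higher number from compound 2 to compound 4 (0.08 log units; within the scatter), that is, no change beyond the scatter, with perhaps a slight drift toward a higher number. Compound 4 is therefore estimated at 6000 nM in this assay, within a range from 2500 nM to 15000 nM.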

Compound 4, half-maximal inhibitory concentration: 9000 nM
For compound 4 the middle estimate is 1.5-fold (0.18 log units) below the measured one; the measured number falls inside the stated range.
By their numbers in this assay, from the lowest: compounds 2, 3, 1 and 4 (each within the scatter of the next).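

Among these compounds, this is the first step in the set that changes a single place, so the oxygen on the aromatic ring can now be read directly: in this assay propanoyl in place of isobutyl gives a 1.8-fold higher number from compound 2 to compound 4 (0.26 log units; within the scatter) and so stays within the scatter. The two groups have the same count of heavy atoms, but propanoyl adds a double bond outside the aromatic rings and a hydrogen-bond acceptor, and in this one pair that swap from isobutoxy to propanoyloxy produces no step beyond the scatter. Nothing in hand explains the result or links the size of this step to any feature of either group.

One pair cannot show how far a group on this oxygen can move the number, or whether any group there can do so at all. As far as these compounds go, it remains open whether a free hydroxyl, a much longer carbon chain or a chain ending in an amine at this place would give a step beyond the scatter.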